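Diethylamino addition on a coumarin-triazole benzenesulfonamide imine

This account rests on a few compounds, and the source may have more. Where it says the series, first, only, none or still open, it means among the compounds named here.

Measured compounds:
compound 1 `C#CCOc1ccccc1/C=N/Cc1ccc(S(N)(=O)=O)cc1` 31000 nM
compound 2 `C#CCOc1cc(N(CC)CC)ccc1/C=N/Cc1ccc(S(N)(=O)=O)cc1` 62800 nM
compound 3 `NS(=O)(=O)c1ccc(C/N=C/c2ccccc2OCc2cn(CCCOc3ccc4ccc(=O)oc4c3)nn2)cc1` 14300 nM

In a functional assay on HT-29 cells (Homo sapiens) for cytotoxicity, read by MTT assay, with a stated time of 24 h (on this read-out lower numbers stand for stronger inhibition and higher numbers for weaker inhibition), compound 1 gives 31000 nM, and compound 2 gives 62800 nM. The change between them is diethylamino in place of hydrogen on an aromatic carbon, and it brought a 2.0-fold higher number from compound 1 to compound 2 (0.31 log units; beyond the scatter). Compound 3 gives 14300 nM in this assay, the lowest of the three numbers; the difference between the core of compound 3 and the core of compound 1 is not broken down here.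

Compound 4 `CCN(CC)c1ccc(/C=N/Cc2ccc(S(N)(=O)=O)cc2)c(OCc2cn(CCCOc3ccc4ccc(=O)oc4c3)nn2)c1` is not yet measured. It differs from compound 3 by diethylamino in place of hydrogen on an aromatic carbon. This is the same kind of change as from compound 1 to compound 2, though there the ring position was meta to a propargyloxy group, whereas here it is meta to a large group. Because of a 2.0-fold higher number from compound 1 to compound 2 (0.31 log units; beyond the scatter), compound 4 is expected to show a 2.0-fold higher number from compound 3 to compound 4 (0.29 log units; within the scatter) in this assay. The estimate for compound 4 is 28000 nM, between 12000 nM and 70000 nM.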

Compound 4, half-maximal inhibitory concentration: 23300 nM
For compound 4 the middle estimate is 1.2-fold (0.08 log units) above the measured one; the measured number falls inside the stated range.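

In this assay, diethylamino in place of hydrogen on an aromatic carbon gave a 1.6-fold higher number from compound 3 to compound 4 (0.21 log units; within the scatter), so on this core the step stays inside the usual scatter. Set beside the earlier step, the two do not differ: the same change on two cores in this assay, a 2.0-fold higher number (0.31 log units; beyond the scatter) from compound 1 to compound 2 and a 1.6-fold higher number (0.21 log units; within the scatter) from compound 3 to compound 4, 1.2-fold (0.09 log units) apart, within the scatter of two such steps. The change therefore carried from one core to the other without a detectable difference in size, but this rests on two pairs in a single assay and shows neither a clear effect on the core of compound 3 nor that the step would hold on other cores. The compounds shown leave open whether dimethylamino or morpholine in the same place would behave alike. They also leave open whether a longer chain in the large group would alter the step.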